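The source may report more compounds than this note shows. Statements on the series, on what has been measured and on what is new or still open speak of the compounds shown alone.

Measured compounds, all in an ADME assay on KB cells (Homo sapiens) for cytotoxicity, with a stated time of 48 h; a lower number here means a stronger inhibitor, a higher number a weaker inhibitor:

- Compound 1 `C=C1[C@H](C)CCC[C@]1(C)CC/C(C)=C/CC1=C(O)C(=O)C=C(N[C@H](CO)C(=O)O)C1=O`: in this assay compound 1 gives > 10 ug/mL, which is a limit of the assay and not a number.
- Compound 2 `C=C1[C@H](C)CCC[C@]1(C)CC/C(C)=C/CC1=C(O)C(=O)C=C(N[C@@H](C(=O)O)[C@@H](C)O)C1=O`: in this assay compound 2 gives > 10 ug/mL, again a limit.
- Compound 3 `C=C1[C@H](C)CCC[C@]1(C)CC/C(C)=C/CC1=C(O)C(=O)C=C(N[C@H](C(=O)O)[C@H](C)O)C1=O`: in this assay compound 3 gives > 10 ug/mL, again a limit.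

The change from compound 2 to compound 1 is hydrogen in place of methyl on a saturated chain carbon bound to an oxygen on a saturated carbon and a saturated chain carbon; its step in this assay is a step that the two limits leave unreadable from compound 2 to compound 1. The step that the two limits leave unreadable from compound 1 to compound 3 is likewise unreadable. Compounds 2 and 3 share the same atoms and bonds, and their cores differ only as the two compounds have the same atoms and bonds and differ only in configuration as drawn: 2 of 5 stereo elements differ; a stereocentre at a saturated chain carbon is drawn R in compound 2 and S in compound 3; a stereocentre at a saturated chain carbon is drawn R in compound 2 and S in compound 3; their step is a step that the two limits leave unreadable from compound 2 to compound 3. All three values sit at the limit, as the limit of > 10 ug/mL in this assay, at which 3 of the 3 values shown sit, records, and the fact that compounds 2 and 3 differ only in the configuration as drawn marks the pair that differs only in configuration.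

Compound 4 `C=C1[C@H](C)CCC[C@]1(C)CC/C(C)=C/CC1=C(O)C(=O)C=C(N[C@@H](CO)C(=O)O)C1=O` is not yet measured. It differs from compound 3 by hydrogen in place of methyl on a saturated chain carbon bound to an oxygen on a saturated carbon and a saturated chain carbon, the same change as that from compound 2 to compound 1, made at a place worded identically. The step expected from compound 3 to compound 4 in this assay is a step that the limit leaves unreadable from compound 3 to compound 4, resting on a step that the two limits leave unreadable from compound 2 to compound 1 and on (the limit of > 10 ug/mL in this assay, at which 3 of the 3 values shown sit), since neither partner of the earlier pair gave a number. Compound 4 is estimated at 20 ug/mL, with a range from 8 ug/mL to 50 ug/mL, most likely reported as a limit.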

Compound 4, half-maximal inhibitory concentration: > 10 ug/mL
Compound 4: no number, only a limit; the forecaster's own chance of this, stated with the estimate: 85%; the middle value does not contradict the limit.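

In this assay compound 4 gives > 10 ug/mL, a limit of the assay and not a number. Its steps from compound 1, compound 2 and compound 3 therefore cannot be read. The compounds shown leave open whether replacing methyl with hydrogen, or changing the configuration as drawn, alters the read-out at all, as none gives a number.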